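The compounds below may be only part of what the source reports. "The series", "measured", "known", "first", "only" and "open" are said of these compounds alone.

Series notes.

Measured so far:
compound 1, `CC1=C(C(=O)Nc2ccc([N+](=O)[O-])cc2)C(c2ccc(Br)cc2)N=C(SCc2ccccc2)N1`: 29.7%
compound 2, `CC1=C(C(=O)Nc2ccc([N+](=O)[O-])cc2)C(c2ccc(Br)cc2)N=C(SCc2ccc(F)cc2)N1`: 34.4%

Both numbers come from a functional assay on the whole organism (artery, strain albino) with Rattus norvegicus as the target, with a stated time of 300 min, at a dose of 10 mg/kg by the oral route; on this read-out lower numbers stand for less inhibition and higher numbers for more inhibition at the one dose given (going by the name of the read-out). For the measured compounds named here, compound 1 stands at one end of the two numbers, compound 2 being the only other, but the one step in hand, a number 4.7 percentage points higher from compound 1 to compound 2 (within the scatter), is within the scatter, so the two cannot be ranked. That step concerns a fluoro in place of hydrogen on an aromatic carbon, not the saturated ring carbon.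

Compound 3 is `CC1=C(C(=O)Nc2ccc([N+](=O)[O-])cc2)C(c2cccc([N+](=O)[O-])c2)N=C(SCc2ccccc2)N1` and awaits measurement in this assay. It differs from compound 1 by 3-nitrophenyl in place of 4-bromophenyl on a saturated ring carbon. Going by the values given here, no measured step touches this position, and neither measured compound carries a nitrophenyl group there, so the only step available, a number 4.7 percentage points higher from compound 1 to compound 2 (within the scatter), bears on it merely as a sign that one change on an aromatic ring has left the read-out within the scatter. On that basis no step beyond the scatter is expected: compound 3 is expected to give 30%, between 12% and 50%, which means an expected step of a number 0.3 percentage points higher from compound 1 to compound 3 (within the scatter). The range is wide, since the change is larger than the one measured and the two numbers give no hold on direction.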

Compound 3, a percentage reported as inhibition, in the whole organism at one dose (the size of the read-out at that dose, not a potency): 25.6%
Compound 3: middle estimate off by 4.4 percentage points, on the high side; the range from low to high includes it.
By their numbers in this assay, from the lowest: compounds 3, 1 and 2 (each within the scatter of the next).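

In this assay, for the compounds shown here, 3-nitrophenyl in place of 4-bromophenyl on the saturated ring carbon gives a number 4.1 percentage points lower from compound 1 to compound 3 (within the scatter), which is the first measured step at this position and lies within the scatter. The exchange is not a small one: the bromine is gone, a nitro group enters, and the entering group has more heavy atoms and carries hydrogen-bond acceptors where the leaving group has none, yet compound 3 and compound 1 cannot be told apart at the one dose given. Nothing at hand offers an explanation for this result.

At this position the compounds shown carry only these two substituted phenyl groups, so it remains open whether an amine or a carboxylic acid on that phenyl ring, or a longer alkyl chain in place of the ring, would give a step beyond the scatter. Also open, as far as these compounds go, is whether the read-out at this position responds at all in this assay, since a single step within the scatter at one dose cannot settle that question, and the benzylsulfanyl group has so far seen only the fluoro change.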